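Metabolic stability across amide variants of the shared core

The source may report more compounds than this note shows. Statements on the series, on what has been measured and on what is new or still open speak of the compounds shown alone.

Measured compounds, with their numbers in an ADME assay on microsomes from liver (Homo sapiens) for metabolic stability, read by LC-MS, using NADPH, with a stated time of 45 min, tested at 0.5 uM; on this read-out lower numbers stand for slow clearance and higher numbers for fast clearance:
- compound 1, `O=C(CCSc1nc2cc(Cl)ccc2o1)N1CCS(=O)(=O)C1`: 1.7 mL/min/g
- compound 2, `O=C(CCSc1nc(-c2ccccc2)co1)N1CCCC1`: 20.9 mL/min/g
- compound 3, `O=C(CCSc1nc2cc(F)c(F)cc2o1)N1CCCC1`: 6.5 mL/min/g

Compound 1 stands lowest of the three in this assay. Compound 3 is the nearest to it, and that gap is beyond the scatter; compound 2 is the furthest away, also beyond the scatter. No pair among these three differs in a single place, so the numbers are read side by side only, and nothing is said here about why they fall where they do.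

The next compound in the series is compound 4, `CN1CCN(C(=O)CCSc2nc3cc(Cl)ccc3o2)CC1`, not yet measured in this assay. Against compound 1 the change is 4-methylpiperazin-1-yl in place of 1,1-dioxo-1,3-thiazolidin-3-yl on a carbonyl carbon.

Among the compounds with values here, with no measured single-point step available, the expectation rests on compound 1 alone and on the size of the change. The amide substituent is swapped wholesale, and an expected step of a 2.1-fold higher number from compound 1 to compound 4 (0.31 log units; beyond the scatter) from compound 1 is set as a modest rise, around the edge of the scatter rather than clearly past it. On that basis compound 4 is estimated to give 3.5 mL/min/g in this assay, with a range from 1.5 mL/min/g to 8 mL/min/g.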

Compound 4, intrinsic clearance in a liver preparation (reported as CLH), per the amount of preparation that the assay uses: 1.5 mL/min/g
Estimate against measurement, compound 4: 2.3-fold (0.37 log units) above, and the stated range covers the measured number.
By their numbers in this assay, from the lowest: compounds 4 and 1 (each within the scatter of the next); then compound 3; then compound 2.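

Within the data shown here, this is the only single-place step so far: on a carbonyl carbon whose other neighbours are a saturated chain carbon, in this assay, 4-methylpiperazin-1-yl in place of 1,1-dioxo-1,3-thiazolidin-3-yl gives a 1.1-fold lower number from compound 1 to compound 4 (0.05 log units; within the scatter) and the two numbers cannot be told apart. The two groups share a heavy-atom count but differ in ring size, in their hetero atoms and in the double bonds outside aromatic rings, so on the core of compound 1 this read-out tolerates a wholesale swap of these two rings without separating them. Nothing measured here bears on why the two compounds read alike.

From the compounds shown here alone, it remains open whether other groups at this carbonyl carbon, such as morpholin-4-yl, piperidin-1-yl or an open-chain dimethylamino group, would read the same on this core. Also open, going by these compounds, is how the pyrrolidin-1-yl amide carried by compound 2 and compound 3 would read on the core of compound 1, and whether the match between compound 1 and compound 4 would hold on a core with a different ring substituent, such as a methoxy group in place of the chlorine.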